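Fluorine Additions on a Shared Amide Core

This account rests on a few compounds, and the source may have more. Where it says the series, first, only, none or still open, it means among the compounds named here.

Compound 1, `O=C(Nc1ccc(Oc2ccnc3[nH]ccc23)cc1)c1cn(-c2ccc(Cl)cc2)c2ccccc2c1=O`, gives 250 nM in a functional assay on HepG2 cells (Homo sapiens) for inhibition, read by MTT assay, with a stated time of 72 h; a lower number here means a stronger inhibitor, a higher number a weaker inhibitor.
Compound 2, `O=C(Nc1ccc(Oc2ccnc3[nH]ccc23)c(F)c1)c1cn(-c2ccc(Cl)cc2)c2ccccc2c1=O`, gives 380 nM in this assay.
Compound 3, `O=C(Nc1ccc(Oc2ccnc3[nH]ccc23)c(F)c1)c1cn(-c2ccc(Br)cc2)c2ccccc2c1=O`, gives 710 nM in this assay.

The move from compound 1 to compound 2 is fluoro in place of hydrogen on an aromatic carbon, and it brought a 1.5-fold higher number from compound 1 to compound 2 (0.18 log units; within the scatter). Compound 3 differs from compound 2 by a 1.9-fold higher number from compound 2 to compound 3 (0.27 log units; within the scatter); how compound 3 differs from compound 1 is not broken down here.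

Compound 4, `O=C(Nc1ccc(Oc2ccnc3[nH]ccc23)c(F)c1)c1cn(-c2ccc(Br)cc2F)c2ccccc2c1=O`, is not yet measured. It differs from compound 3 by fluoro in place of hydrogen on an aromatic carbon. Going by the values given here, this is the same kind of change as the one between compound 1 and compound 2, though the surroundings differ: in the earlier case the new fluoro sits meta to a large group, here it sits meta to a bromo group (1 heavy atom).

Compound 4 is expected to show a 1.3-fold higher number from compound 3 to compound 4 (0.10 log units; within the scatter) in this assay, because the same kind of change earlier gave a 1.5-fold higher number from compound 1 to compound 2 (0.18 log units; within the scatter). On that basis compound 4 is estimated at 900 nM, likely between 450 nM and 1800 nM.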

Compound 4, half-maximal inhibitory concentration: 2200 nM
For compound 4 the middle estimate is 2.4-fold (0.39 log units) below the measured one, and the stated range ends below it.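

Adding fluoro to the 4-bromophenyl group gave a 3.1-fold higher number from compound 3 to compound 4 (0.49 log units; beyond the scatter) in this assay, and the wider swap of 4-chlorophenyl for 4-bromo-2-fluorophenyl on the aromatic nitrogen gave a 5.8-fold higher number from compound 2 to compound 4 (0.76 log units; beyond the scatter). Going by these compounds alone, although only the new fluoro step lies beyond the scatter by itself, the two fluoro steps cannot be told apart, so nothing here shows that the core alters the outcome of this change: the same change on two cores in this assay, a 1.5-fold higher number (0.18 log units; within the scatter) from compound 1 to compound 2 and a 3.1-fold higher number (0.49 log units; beyond the scatter) from compound 3 to compound 4, 2.0-fold (0.31 log units) apart, within the scatter of two such steps This does not show that the change acts identically on both cores or would carry to further ones, since it rests on only two pairs of compounds, and the fluoro enters a different aromatic ring in each pair.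

The compounds shown leave open whether the same fluoro would act alike on the 4-chlorophenyl group of compound 2. They also leave open how a methoxy group or an amine would fare in the fluoro's place on the 4-bromophenyl group of compound 3.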